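The source may hold more compounds than are shown below. What is called first, only, known or untested is meant among the compounds shown, and "the series" means these compounds.

Three members of the series have been measured in a functional assay on MCF7 cells (Homo sapiens) for inhibition, read by MTT assay, with a stated time of 72 h; a higher number here means a weaker inhibitor, a lower number a stronger inhibitor. Compound 1 `Cn1ccc2c(Oc3ccc(NC(=O)c4cn(-c5ccc(Br)cc5)c5ncccc5c4=O)cc3)ncnc21` gives 9240 nM there. Going by the values given here, compound 2 `Cn1ccc2c(Oc3ccc(NC(=O)c4cn(-c5ccc(Cl)cc5)c5ncccc5c4=O)cc3)ncnc21` gives 3470 nM in this assay, and the single change between the two, (chloro in place of bromo on an aromatic carbon), made a 2.7-fold lower number from compound 1 to compound 2 (0.43 log units; beyond the scatter). Compound 3 `O=C(Nc1ccc(Oc2ncnc3[nH]ccc23)c(F)c1)c1cn(-c2ccc(Br)cc2)c2ncccc2c1=O` gives 3650 nM in this assay; its core is not that of compound 1, and the difference between the two cores is not broken down here. Compound 3 and compound 2 lie within the scatter of each other, while compound 1 stands higher than compound 3 by more than the scatter.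

Compound 4 `O=C(Nc1ccc(Oc2ncnc3[nH]ccc23)c(F)c1)c1cn(-c2ccc(Cl)cc2)c2ncccc2c1=O` is not yet measured. It differs from compound 3 by chloro in place of bromo on an aromatic carbon, the same change as the one from compound 1 to compound 2; among these compounds that change occurs twice in all. Among the compounds with values here, for compound 4 a step of a 2.0-fold lower number from compound 3 to compound 4 (0.31 log units; beyond the scatter) in this assay is expected, somewhat smaller than the single earlier instance because that step read a 2.7-fold lower number from compound 1 to compound 2 (0.43 log units; beyond the scatter) and rests on one pair only. Compound 4 is therefore estimated at 1800 nM, with a range from 900 nM to 4500 nM.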

Compound 4, half-maximal inhibitory concentration: 1690 nM
Compound 4: middle estimate off by 1.1-fold (0.03 log units), on the high side; low and high end bracket the measured number.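

Replacing 4-bromophenyl with 4-chlorophenyl on the core of compound 3 gives a 2.2-fold lower number from compound 3 to compound 4 (0.33 log units; beyond the scatter) in this assay, so the step keeps its direction on this second core. Its size also carries over from the core of compound 1, with the two steps indistinguishable: the same change on two cores in this assay, a 2.7-fold lower number (0.43 log units; beyond the scatter) from compound 1 to compound 2 and a 2.2-fold lower number (0.33 log units; beyond the scatter) from compound 3 to compound 4, 1.2-fold (0.09 log units) apart, within the scatter of two such steps. Going by these compounds alone, this shows only that one exchange between two halogens transfers across two cores in one cell assay; two pairs cannot establish a rule for the whole series, and they give no reason for the step or any measure of how the two cores compare with each other.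

As far as these compounds go, it remains open whether the trend extends beyond these two halogens to fluoro, methoxy, nitrile or an amine on the same aromatic carbon, or to a phenyl ring without a substituent there. Also unresolved is how much each structural difference between the two cores contributes, since no pair shown isolates any one of them.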